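Moving the Chlorine on the Phenyl Ring of Compound 3

The compounds below may be only part of what the source reports. "The series", "measured", "known", "first", "only" and "open" are said of these compounds alone.

For the measured compounds named here, compound 3 `Clc1cccc(-c2cc(-c3ccc(Cl)o3)cc(-c3cccs3)n2)c1` gives 42% in an assay on isolated protein for inhibition of DNA topoisomerase 1 (Homo sapiens), tested at 100 uM (a lower number here means a weaker effect, a higher number a stronger effect of the compound at the concentration tested), the highest of the three numbers measured so far. Compound 1 `Clc1ccc(-c2cc(-c3cccnc3)nc(-c3cccs3)c2)o1` gives 25.8% in this assay, and compound 2 `Clc1ccc(-c2cc(-c3ccoc3)cc(-c3cccs3)n2)cc1` gives 0%. The only step measured between two of these compounds is a number 16.2 percentage points higher from compound 1 to compound 3 (beyond the scatter), so exchanging a pyridin-3-yl for a 3-chlorophenyl group raised the read-out by a modest amount.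

Compound 4 `Clc1ccc(-c2cc(-c3ccc(Cl)o3)cc(-c3cccs3)n2)cc1` differs from compound 3 in one place: 4-chlorophenyl in place of 3-chlorophenyl on an aromatic carbon. Going by the values given here, no measured step exchanges 3-chlorophenyl for 4-chlorophenyl, so the size and direction of this change cannot be read from the earlier numbers. Among the compounds with values here, the only measured compound that carries a 4-chlorophenyl group, compound 2, shows a weak effect, but it also differs from compound 4 in a second ring, so it gives no clean comparison.

Within the data shown here, with no direct precedent, compound 4 is estimated at 28%, within a wide range from 5% to 50%, which means an expected step of a number 14 percentage points lower from compound 3 to compound 4 (beyond the scatter).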

Compound 4, a percentage reported as inhibition, at one concentration (the size of the read-out at that concentration, not a potency): 38.9%
For compound 4 the middle estimate is 10.9 percentage points below the measured one; low and high end bracket the measured number.
By their numbers in this assay, from the lowest: compound 2; then compound 1; then compounds 4 and 3 (each within the scatter of the next).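

Exchanging 3-chlorophenyl for 4-chlorophenyl at this position gives a number 3.1 percentage points lower from compound 3 to compound 4 (within the scatter) in this assay and so shows that the two chlorophenyl groups cannot be told apart here. The 4-chlorophenyl group also stands well clear of pyridin-3-yl, with a number 13.1 percentage points higher from compound 1 to compound 4 (beyond the scatter) as the step, which matches what 3-chlorophenyl showed in the earlier comparison. For the compounds shown here, compound 2 now has a partner that differs from it in one place, and 5-chlorofuran-2-yl in place of furan-3-yl gives a number 38.9 percentage points higher from compound 2 to compound 4 (beyond the scatter) as a far larger step than the one between the chlorophenyl groups, so in this small set the second ring separates the compounds more clearly than the place of the chlorine.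

Still open, going by these compounds, is how a phenyl ring carrying an amine or a carboxylic acid instead of chlorine would behave at this position. No measurement shown here explains any of these steps.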